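This account rests on a few compounds, and the source may have more. Where it says the series, first, only, none or still open, it means among the compounds named here.

Measured compounds:
Compound 1, `CS(=O)(=O)N1CCN(CC(O)CN2CCC(NC(=O)c3cccc4[nH]cnc34)CC2)CC1`, gives 631 nM.
Compound 2, `CS(=O)(=O)N1CCN(CC(O)CN2CCC(CNC(=O)c3cccc4[nH]c(C5CC5)nc34)CC2)CC1`, gives 0.631 nM.
Compound 3, `CC(C)c1nc2c(C(=O)NCC3CCN(CCN4CCN(S(C)(=O)=O)CC4)CC3)cccc2[nH]1`, gives 0.794 nM.

In a functional assay for agonist activity at 5-hydroxytryptamine receptor 4 (Homo sapiens), read by cAMP accumulation (on this read-out higher numbers stand for an effect only at larger amounts of compound and lower numbers for an effect already at smaller amounts), compound 3 holds the second highest of the three numbers. Its nearest neighbour is compound 2, whose number lies within the usual scatter of compound 3, so nothing can be said of an order between the two. Compound 1, by contrast, stands far beyond the scatter on the high side of compound 3; compound 1 also differs from compound 3 in more than one place, so its two values alone are reported here without any attribution to a single change.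

Compound 4, `COC(=O)N(C)CC(O)CN1CCC(CNC(=O)c2cccc3[nH]c(C(C)C)nc23)CC1`, has not yet been measured. It differs from compound 3 in one place: 1-hydroxy-2-((methoxycarbonyl)(methyl)amino)ethyl in place of (4-(methylsulfonyl)piperazin-1-yl)methyl on a saturated chain carbon bound to an amine nitrogen in a ring. Among the measured compounds shown here, no measured pair isolates this change. On these data alone, compound 2 carries a hydroxy-bearing chain and yet gives a low number, which suggests the chain itself need not cost much in this assay; what the loss of the ring-bearing group costs is unknown. A moderate step upward beyond the scatter is expected, a 3.8-fold higher number from compound 3 to compound 4 (0.58 log units; beyond the scatter). Compound 4 is therefore estimated at 3 nM, within a range of 0.5 nM to 20 nM.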

Compound 4, half-maximal effective concentration: 2 nM
For compound 4 the middle estimate is 1.5-fold (0.18 log units) above the measured one, within the range that was stated.
By their numbers in this assay, from the lowest: compounds 2 and 3 (each within the scatter of the next); then compound 4; then compound 1.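

In this assay, the series now has its first comparison that changes one place only: a 2.5-fold higher number from compound 3 to compound 4 (0.40 log units; beyond the scatter), with 1-hydroxy-2-((methoxycarbonyl)(methyl)amino)ethyl in place of (4-(methylsulfonyl)piperazin-1-yl)methyl on a saturated chain carbon bound to an amine nitrogen in a ring. The step is modest but beyond the usual scatter, so this place does respond to the exchange, yet the six-membered non-aromatic ring and the sulfur of the leaving group can both go with only this limited shift, and compound 4 still gives 2 nM with an open chain. Nothing measured on these compounds bears on the origin of this step.

On these data alone, the whole group changes at once, so it remains open whether the hydroxy group or the methoxycarbonyl of the entering chain accounts for the step, and what a primary amine, a carboxylic acid or a longer unbranched alkyl chain would give at this place. Also open, as far as these compounds go, is whether the same exchange would give a step of similar size on the core of compound 2.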